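The source may hold more compounds than are shown below. What is called first, only, known or untested is meant among the compounds shown, and "the series" means these compounds.

Working notes on the series. For the measured compounds named here, compound 1 `C[C@H]1[C@H](NCc2ccc(Cl)s2)C[C@H]2C[C@@H]1C2(C)C` is one of two compounds measured in an ADME assay on MDCK cells (Canis lupus familiaris) for cytotoxicity, read by microscopy, with a stated time of 48 h (a lower number here means that less compound is tolerated, a higher number that more compound is tolerated), where compound 1 gives 25000 nM. The other is compound 2 `C=Cc1ccsc1CN[C@@H]1C[C@H]2C[C@@H]([C@H]1C)C2(C)C`, which in this assay gives 50000 nM. Compound 1 holds the lower of the two numbers, but the gap to compound 2 lies within the usual scatter, so the two are not told apart by this assay. Going by the values given here, no step between measured compounds that differ in one place is available, so nothing about the effect of a single change has yet been seen.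

Compound 3 `C[C@H]1[C@H](NCc2ccoc2)C[C@H]2C[C@@H]1C2(C)C` is not yet measured in this assay. It differs from compound 1 as follows: furan-3-yl in place of 5-chlorothiophen-2-yl on a saturated chain carbon bound to an amine nitrogen. Among the compounds with values here, with no comparable step in hand, the expectation rests on the two values seen, both of which fall close together, and the step of a 1.4-fold higher number from compound 1 to compound 3 (0.15 log units; within the scatter) is expected to be no larger than the scatter, in either direction. Compound 3 is therefore estimated at 35000 nM in this assay, within a range of 12000 nM to 120000 nM.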

Compound 3, minimum cytotoxic concentration: > 100000 nM
Compound 3: only a limit was reported (the forecaster's own chance of this, stated with the estimate: 25%); middle value at least 2.8-fold (0.45 log units) from the limit.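

In this assay, for the compounds shown here, furan-3-yl in place of 5-chlorothiophen-2-yl on a saturated chain carbon bound to an amine nitrogen gives an at least 4.0-fold higher number from compound 1 to compound 3 (0.60 log units; beyond the scatter): this is the first change in one place to be read and the first gap beyond the scatter, which compound 1 and compound 2 could not provide, their values lying within the scatter of each other. Compound 3 gives > 100000 nM, which is a limit of the assay and not a number. The group at this place therefore matters for the concentration tolerated, but the step gives only a minimum size, with its true extent unknown: the limit of > 100000 nM in this assay, at which 1 of the 3 values shown sits.

The change removes the chlorine, replaces the sulfur of the ring with oxygen and moves the point of attachment all at once, and the compounds shown do not separate these parts. As far as these compounds go, whether a plain thiophen-2-yl, a furan-2-yl or a phenyl ring at this place would read like compound 1 or like compound 3 remains open.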